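Chloro in place of hydrogen: expected shift for compound 4

This account rests on a few compounds, and the source may have more. Where it says the series, first, only, none or still open, it means among the compounds named here.

Measured compounds, antiproliferative read-out:
compound 1 `Cc1nc2c([nH]1)C(=O)/C(=N/c1ccc(F)cc1)C(Cl)=C2O` gives 1200 nM
compound 2 `Cc1nc2c([nH]1)C(=O)/C(=N/c1cccc(Br)c1)C(Cl)=C2O` gives 800 nM
compound 3 `Cc1nc2c([nH]1)C(=O)/C(=N/c1ccccc1)C(Cl)=C2O` gives 5200 nM

Compound 3 stands at the highest of the three numbers in a functional assay on NIH3T3 cells (Mus musculus) for antiproliferative activity (a lower number here means a stronger inhibitor, a higher number a weaker inhibitor), the unsubstituted phenyl ring being the only point of difference from the other two. Both steps that end at compound 3 run upward and beyond the scatter: a 4.3-fold higher number from compound 1 to compound 3 (0.64 log units; beyond the scatter) and a 6.5-fold higher number from compound 2 to compound 3 (0.81 log units; beyond the scatter). Between the two halogenated compounds the gap is small, a 1.5-fold lower number from compound 1 to compound 2 (0.18 log units; within the scatter), so within this set a halogen on the phenyl ring matters more than which halogen or where it sits.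

Compound 4 `Cc1nc2c([nH]1)C(=O)/C(=N/c1cccc(Cl)c1)C(Cl)=C2O` differs from compound 3 by chloro in place of hydrogen on an aromatic carbon. The step is the reverse of the two removals above, and chloro sits between fluoro and bromo in the halogen series. A downward step of comparable size is therefore expected in this assay, a 5.8-fold lower number from compound 3 to compound 4 (0.76 log units; beyond the scatter), landing near the two halogenated compounds. The estimate for compound 4 is 900 nM, with a range from 400 nM to 2500 nM.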

Compound 4, half-maximal inhibitory concentration: 1600 nM
Beside the measured number, compound 4's estimate is 1.8-fold (0.25 log units) below it; low and high end bracket the measured number.
By their numbers in this assay, from the lowest: compounds 2, 1 and 4 (each within the scatter of the next); then compound 3.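

In this assay, the step of a 3.3-fold lower number from compound 3 to compound 4 (0.51 log units; beyond the scatter) shows that chloro, like fluoro and bromo, separates from the unsubstituted phenyl beyond the scatter, so all three halogenated compounds shown now share this gain. Compound 2 and compound 4 carry their halogens on the same aromatic carbon, and the step of a 2.0-fold higher number from compound 2 to compound 4 (0.30 log units; within the scatter) lies within the scatter, as does a 1.3-fold higher number from compound 1 to compound 4 (0.12 log units; within the scatter), so neither the swap of bromo for chloro nor the move from 4-fluorophenyl to 3-chlorophenyl resolves a difference here. The data shown offer no measurement that explains these steps.

Going by these compounds, whether the gain requires a halogen remains open, and methyl, methoxy or an amine on the same aromatic carbon would address that. Also open, on these data alone, is how the 3-fluorophenyl and 4-chlorophenyl rings compare.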